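The source may report more compounds than this note shows. Statements on the series, on what has been measured and on what is new or still open speak of the compounds shown alone.

Measured so far in a functional assay on HepG2 cells (Homo sapiens) for cytotoxicity, read by MTT assay, with a stated time of 72 h; on this read-out higher numbers stand for lower toxicity in this test and lower numbers for higher toxicity in this test:
- compound 1 `CS/C(=N\C(=O)c1csc([N+](=O)[O-])c1)NC(=O)c1csc([N+](=O)[O-])c1`: compound 1 gives > 100000 nM, a limit of the assay.
- compound 2 `CS/C(=N\C(=O)c1ccno1)NC(=O)c1ccno1`: compound 2 gives > 100000 nM, a limit of the assay.
- compound 3 `O=C(/N=C(/NC(=O)c1ccno1)[Se]Cc1ccccc1)c1ccno1`: compound 3 gives > 100000 nM, a limit of the assay.

Compound 3 thus stands only at a limit in this assay, together with every other value shown (the limit of > 100000 nM in this assay, at which 3 of the 3 values shown sit). Going by the values given here, the single step among the measured compounds, a step that the two limits leave unreadable from compound 2 to compound 3, is itself unreadable because both ends are limits.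

Compound 4 `C[Se]/C(=N\C(=O)c1ccno1)NC(=O)c1ccno1` differs from compound 3 by hydrogen in place of phenyl on a saturated chain carbon bound to a selenium atom; cut one bond further out, benzyl to methyl. The change touches the same selenium-bearing group that the unreadable step altered, so the measured data give no readable size or direction for it. Compound 4 is expected to sit at the limit as well, with the step that the limit leaves unreadable from compound 3 to compound 4 expected to be none beyond the scatter. Estimate for compound 4: 150000 nM, range 60000 nM to 400000 nM.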

Compound 4, concentration lethal to 50% of the cells: > 100000 nM
Compound 4 ended at the assay's limit; the forecaster's own chance of this, stated with the estimate: 85%; the middle value lies beyond the limit too.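

Going by these compounds alone, no step among compound 2, compound 3 and compound 4 can be read, since each value is a limit and not a number: the limit of > 100000 nM in this assay, at which 4 of the 4 values shown sit. The compounds shown leave open how far any of them lies past that limit.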